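This account rests on a few compounds, and the source may have more. Where it says the series, first, only, none or still open, it means among the compounds named here.

Measured so far in an ADME assay on Vero C1008 cells (Chlorocebus sabaeus) for cytotoxicity, read by luminescence and CellTiter-Glo, with a stated time of 24 h; a higher number here means that more compound is tolerated, a lower number that less compound is tolerated:
compound 1 `C[C@H](OC(=O)N[C@@H](CC1CC1)C(=O)N[C@H](C=O)C[C@@H]1CCNC1=O)c1ccccc1`: > 200000 nM
compound 2 `O=C(N[C@@H](CC1CC1)C(=O)N[C@@H](C[C@@H]1CCNC1=O)C(O)S(=O)(=O)O)OCCc1cccc(Cl)c1`: > 200000 nM

In this assay compound 1 gives > 200000 nM, which is a limit of the assay and not a number. Compound 2 gives > 200000 nM in this assay, likewise a limit. Among the measured compounds shown here, compound 2 thus stands at a limit, and the one further value shown is also a limit: both sit at the limit of > 200000 nM in this assay, at which 2 of the 2 values shown sit. For the measured compounds named here, no step between measured compounds is available, so no measured size of change exists.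

Compound 3 `C[C@H](OC(=O)N[C@@H](CC1CC1)C(=O)N[C@@H](C[C@@H]1CCNC1=O)C(O)S(=O)(=O)O)c1ccccc1` differs from compound 2 in one place: 1-phenylethyl in place of 2-(3-chlorophenyl)ethyl on an oxygen next to a carbonyl group. Compound 1 already carries 1-phenylethyl on an oxygen next to a carbonyl group and sits at the same limit. No step beyond the scatter is expected in this assay, in either direction, given that both values shown rest at the limit of > 200000 nM in this assay, at which 2 of the 2 values shown sit. The expected step from compound 2 to compound 3 is a number no higher from compound 2 to compound 3 (the limit leaves the size open). For compound 3 the estimate in this assay is 200000 nM, between 100000 nM and 400000 nM, most probably reported again as a limit.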

Compound 3, half-maximal cytotoxic concentration: > 200000 nM
Compound 3 gave a limit, no number (the forecaster's own chance of this, stated with the estimate: 85%); the middle value sits exactly at the limit.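

In this assay no new step can be read for compound 3 from either compound 2 or compound 1, as each value is a limit and not a number: the limit of > 200000 nM in this assay, at which 3 of the 3 values shown sit.

The compounds shown leave open where the half-maximal cytotoxic concentration of any of them lies and whether either change in structure alters it.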